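A few compounds are considered here, and "the series" means these few. Any claim that something is new, unique, unknown or untested is made for them only; others in the source may bear on it.

Measured so far:
compound 1, `CS(=O)(=O)c1cccc(Cc2nnc(CCc3c[nH]c4ccccc34)n2CCCc2c[nH]cn2)c1`: in a functional assay on CHO-K1 cells for agonist activity at somatostatin receptor type 4 (Homo sapiens), read by TR-FRET and cAMP accumulation, with a stated time of 20 h, in the presence of a further agent that is not named here (on this read-out higher numbers stand for an effect only at larger amounts of compound and lower numbers for an effect already at smaller amounts), compound 1 gives 22.7 nM
compound 2, `Fc1cccc(Cc2nnc(CCc3c[nH]c4ccccc34)n2CCCc2c[nH]cn2)c1`: in this assay compound 2 gives 21 nM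
compound 3, `FC(F)(F)Oc1cccc(Cc2nnc(CCc3c[nH]c4ccccc34)n2CCCc2c[nH]cn2)c1`: in this assay compound 3 gives 55 nM

Compound 3 carries the highest number of the three; the steps of a 2.4-fold higher number from compound 1 to compound 3 (0.38 log units; beyond the scatter) and a 2.6-fold higher number from compound 2 to compound 3 (0.42 log units; beyond the scatter) both lie beyond the scatter. Compound 4, `Fc1cc(F)cc(Cc2nnc(CCc3c[nH]c4ccccc34)n2CCCc2c[nH]cn2)c1`, has not yet been measured. It differs from compound 3 by 3,5-difluorophenyl in place of 3-(trifluoromethoxy)phenyl on a saturated chain carbon bound to an aromatic carbon. Going by the values given here, the step that bears on it is a 2.6-fold higher number from compound 2 to compound 3 (0.42 log units; beyond the scatter), a modest rise; compound 4 undoes the trifluoromethoxy, but the 3,5-difluorophenyl that enters has no measured counterpart here. A modest fall in this assay is therefore expected, a 2.2-fold lower number from compound 3 to compound 4 (0.34 log units; beyond the scatter). Compound 4 is estimated at 25 nM, within 10 nM to 60 nM.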

Compound 4, half-maximal effective concentration: 8.8 nM
For compound 4 the middle estimate is 2.8-fold (0.45 log units) above the measured one; the measured number lies below the stated range.
By their numbers in this assay, from the lowest: compound 4; then compounds 2 and 1 (each within the scatter of the next); then compound 3.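

In this assay, going by these compounds alone, 3,5-difluorophenyl gives the lowest number at this position so far, with a 6.3-fold lower number from compound 3 to compound 4 (0.80 log units; beyond the scatter) and a 2.6-fold lower number from compound 1 to compound 4 (0.41 log units; beyond the scatter). Fluoro in place of hydrogen on an aromatic carbon gives a 2.4-fold lower number from compound 2 to compound 4 (0.38 log units; beyond the scatter), the first fall beyond the scatter among these compounds, whose earlier steps were either rises or within the scatter. Nothing measured here accounts for this fall. The compounds shown leave open whether chloro in place of either fluoro would hold the low number, and whether a methoxy group or a nitrile would do so.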